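The source may hold more compounds than are shown below. What is called first, only, known or untested is meant among the compounds shown, and "the series" means these compounds.

Compound 2 `NCCCC[C@H](NC(=O)CN(c1nc(Cl)nc2[nH]cnc12)C1CC1)C(=O)OCc1ccccc1` gives 9.19% in a functional assay on the whole organism (Tail, strain ICR) with Mus musculus as the target, in the tail flick test, with a stated time of 30 min, at a dose of 6.25 umol/kg by the oral route; a higher number here means a stronger effect of the compound at the dose given, a lower number a weaker effect. Compound 1 `N=C(N)NCCC[C@H](NC(=O)CN(c1nc(Cl)nc2[nH]cnc12)C1CC1)C(=O)O` gives 8.9% in this assay; the two numbers lie within the scatter of each other, so neither stands apart. Compound 3 `NCCCC[C@H](NC(=O)CN(c1nc(Cl)nc2[nH]cnc12)C1CC1)C(=O)O` is not yet measured. Against compound 2 the change is hydrogen in place of benzyl on an oxygen next to a carbonyl group, benzyloxycarbonyl to carboxy. Among the compounds with values here, no step between measured compounds is available to size this change. In this assay the step of a number 0.2 percentage points lower from compound 2 to compound 3 (within the scatter) is expected to stay inside the scatter. This expectation rests on compound 1, which already carries the carboxy group and gives 8.9%. Compound 3 is therefore expected to give 9%, between 0% and 20%.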

Compound 3, a percentage reported as activity, at one dose (the size of the read-out at that dose, not a potency): 8.04%
For compound 3 the middle estimate is 1 percentage points above the measured one, and the stated range covers the measured number.
By their numbers in this assay, from the lowest: compounds 3, 1 and 2 (each within the scatter of the next).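

In this assay, hydrogen in place of benzyl on an oxygen next to a carbonyl group gives a number 1.2 percentage points lower from compound 2 to compound 3 (within the scatter), so this first sized step at this position does not separate the benzyloxycarbonyl and carboxy forms. With the carboxy group held constant, a group of 2 heavy atoms in place of a group of 4 heavy atoms on the saturated chain carbon gives a number 0.9 percentage points lower from compound 1 to compound 3 (within the scatter), which also stays unresolved. Neither change moves the read-out beyond the scatter at this single dose and time.

Open, from the compounds shown here alone, is whether a methyl or ethyl group on the same oxygen would behave likewise. No measurement at hand accounts for these small steps.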